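The source may hold more compounds than are shown below. What is called first, only, known or untested is meant among the compounds shown, and "the series" means these compounds.

Measured compounds in the series:
compound 1 `CC1CCCc2ncc(C(=O)O)c(=O)n21` — 240 umol/kg
compound 2 `CC1CCC(/C=N/c2ccc(F)cc2)=C2NC=C(C(=O)O)C(=O)N21` — 10.6 umol/kg
compound 3 `Cc1cccc(/N=C/C2=C3NC=C(C(=O)O)C(=O)N3C(C)CC2)c1` — 0.8 umol/kg

All three were run in a functional assay on the whole organism with Rattus norvegicus as the target; on this read-out lower numbers stand for an effect already at smaller amounts and higher numbers for an effect only at larger amounts of compound. Compound 2 stands second highest of the three numbers: compound 3 is its nearest neighbour with a step of a 13-fold lower number from compound 2 to compound 3 (1.12 log units; beyond the scatter), and compound 1 is the furthest away with a higher number beyond the scatter. The unmeasured compound 4 `CC1CCC(/C=N/c2ccc(CC(=O)O)cc2)=C2NC=C(C(=O)O)C(=O)N21` is reached from compound 2 by one change, (carboxymethyl in place of fluoro on an aromatic carbon).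

Among the compounds with values here, the only measured step at the same ring is the one from compound 2 to compound 3, where a change of the aryl group moved the number beyond the scatter, so substitution on this ring can matter. Within the data shown here, no measured compound carries carboxymethyl or any group of that kind, and no step shows what an acid at that place does in this assay. The direction for compound 4 therefore cannot be taken from the shown steps, and the expectation is set close to compound 2 with a wide range. Compound 4 is expected to give 13 umol/kg (range 3 umol/kg to 60 umol/kg). This estimate means a step of a 1.2-fold higher number from compound 2 to compound 4 (0.09 log units; within the scatter), within the scatter.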

Compound 4, dose for 50% inhibition: 5.8 umol/kg
Compound 4: the middle estimate sits 2.2-fold (0.35 log units) above what was measured; measured number inside the range.
By their numbers in this assay, from the lowest: compound 3; then compounds 4 and 2 (each within the scatter of the next); then compound 1.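

In this assay, carboxymethyl in place of fluoro on the aromatic carbon para to a large group gives a 1.8-fold lower number from compound 2 to compound 4 (0.26 log units; within the scatter). Within the data shown here, this carbon therefore accepts a side chain carrying a carboxylic acid without a step beyond the scatter, whereas the only earlier change of this aryl group gave a 13-fold lower number from compound 2 to compound 3 (1.12 log units; beyond the scatter). No measurement on these compounds speaks to the reason for this result.

Open, going by these compounds, is whether a carboxylic acid set directly on the ring, a longer chain such as carboxyethyl, or an amine such as aminomethyl at this carbon would also stay within the scatter of compound 2. Also open, on these data alone, is whether carboxymethyl on the 3-methylphenyl ring would preserve the number of compound 3, 0.8 umol/kg.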